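Methyl ester versus free acid: cytotoxicity notes

A few compounds are considered here, and "the series" means these few. Any claim that something is new, unique, unknown or untested is made for them only; others in the source may bear on it.

Compound 1 `COC(=O)c1ccc(CN2C(=O)/C(=C/c3cc(C)n(-c4ccc(O)c(C(=O)O)c4)c3C)SC2=S)cc1` and compound 3 `COC(=O)c1cccc(CN2C(=O)/C(=C/c3cc(C)n(-c4ccc(O)c(C(=O)O)c4)c3C)SC2=S)c1` are built from the same atoms joined differently: 3-(methoxycarbonyl)phenyl in place of 4-(methoxycarbonyl)phenyl on a saturated chain carbon bound to an amide-type nitrogen in a ring. In an ADME assay on MT2 cells (Homo sapiens) for cytotoxicity, read by XTT assay, with a stated time of 4 days (on this read-out higher numbers stand for lower toxicity in this test and lower numbers for higher toxicity in this test), compound 1 gives 36900 nM and compound 3 gives 38500 nM; the step between them is a 1.0-fold higher number from compound 1 to compound 3 (0.02 log units; within the scatter). Compound 2 `Cc1cc(/C=C2\SC(=S)N(Cc3ccc(C(=O)O)cc3)C2=O)c(C)n1-c1ccc(O)c(C(=O)O)c1` carries on the core of compound 1 the change (hydrogen in place of methyl on an oxygen next to a carbonyl group); in this assay compound 2 gives 105000 nM, a step of a 2.8-fold higher number from compound 1 to compound 2 (0.45 log units; beyond the scatter). From compound 2 to compound 3 the step reads a 2.7-fold lower number from compound 2 to compound 3 (0.44 log units; beyond the scatter).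

Compound 4 `Cc1cc(/C=C2\SC(=S)N(Cc3cccc(C(=O)O)c3)C2=O)c(C)n1-c1ccc(O)c(C(=O)O)c1` is not yet measured. Among the compounds with values here, it carries on the core of compound 3 the change (hydrogen in place of methyl on an oxygen next to a carbonyl group), the same change as the one from compound 1 to compound 2, at a place described in the same words, so it counts as the same change, seen twice in this set. Because of a 2.8-fold higher number from compound 1 to compound 2 (0.45 log units; beyond the scatter) the step expected for compound 4 in this assay is a 2.7-fold higher number from compound 3 to compound 4 (0.44 log units; beyond the scatter); this rests on that single earlier case only. The estimate for compound 4 in this assay is 105000 nM, expected to fall between 50000 nM and 220000 nM.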

Compound 4, half-maximal cytotoxic concentration: > 100000 nM
Compound 4 gave a limit, no number; the forecaster's own chance of this, stated with the estimate: 20%; the middle value is on the limit's open side.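

In this assay compound 4 gives > 100000 nM, which is a limit of the assay and not a number. The change from methoxycarbonyl to carboxy again goes with a higher number, which on this read-out stands for lower toxicity in this test: an at least 2.5-fold higher number from compound 3 to compound 4 (0.41 log units; beyond the scatter), and the wider comparison across both differences gives an at least 2.7-fold higher number from compound 1 to compound 4 (0.43 log units; beyond the scatter). The direction of the change therefore carries over from the core of compound 1 to the core of compound 3, but equal size on the two cores is not shown, and the step from compound 2 to compound 4 cannot be read: the same change on two cores in this assay, a 2.8-fold higher number (0.45 log units; beyond the scatter) from compound 1 to compound 2 and an at least 2.5-fold higher number (0.41 log units; beyond the scatter) from compound 3 to compound 4; the limit leaves it open whether they differ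

As far as these compounds go, two pairs of compounds are a small base, so it stays open whether the same direction would hold on a core with the ester group elsewhere on the ring or with a different linking chain. From the compounds shown here alone, it also stays open whether a longer ester such as ethoxycarbonyl, or a primary amide in place of the carboxy group, would read like the methyl esters or like the free acids.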